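This account rests on a few compounds, and the source may have more. Where it says the series, first, only, none or still open, it means among the compounds named here.

Two compounds in this series have a result in an assay on HEK293 cells for antagonist activity at P2X purinoceptor 7 (Homo sapiens), read by fluorescence, with a stated time of 2 h; on this read-out higher numbers stand for weaker inhibition and lower numbers for stronger inhibition. Compound 1, `O=C(Oc1ccc(-c2cncn2C2CCN(C(=O)c3ccc(Cl)c(C(F)(F)F)c3)CC2)cc1)c1ccccc1`, reaches only a limit: in this assay compound 1 gives > 10000 nM, which marks the edge of what the assay reports rather than a measured number. For the measured compounds named here, compound 2, `CS(=O)(=O)c1ccc(C(=O)N2CCC(n3cncc3-c3ccc(OS(=O)(=O)c4cccc5cnccc45)cc3)CC2)cc1`, is the one compound with a proper number: in this assay compound 2 gives 25 nM. Compound 2 therefore stands as the only measured figure in the set, the other entry being a limit, as the line the limit of > 10000 nM in this assay, at which 1 of the 2 values shown sits, records. Compound 3, `N#Cc1ccc(C(=O)N2CCC(n3cncc3-c3ccc(OS(=O)(=O)c4cccc5cnccc45)cc3)CC2)cc1`, has not yet been measured in this assay. It differs from compound 2 in one place: cyano in place of methylsulfonyl on an aromatic carbon, a cyano in place of methylsulfonyl on an aromatic carbon. No measured pair in the set shows a step of this kind, so no shown step tells what to expect. The account expects the step from compound 2 to compound 3 to be a 1.6-fold higher number from compound 2 to compound 3 (0.20 log units; within the scatter), which lies within the usual scatter. For compound 3 in this assay the expected value is 40 nM, with a range from 10 nM to 160 nM.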

Compound 3, half-maximal inhibitory concentration: 269 nM
The estimate for compound 3 lay 6.7-fold (0.83 log units) below the measured number; measured number outside the range, above it.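

In this assay, for the compounds shown here, the aromatic carbon para to a large group proves sensitive to what it carries: cyano in place of methylsulfonyl gives an 11-fold higher number from compound 2 to compound 3 (1.03 log units; beyond the scatter), the only step in the set between compounds that differ in one place. Compound 1 and compound 2 differ in more than one place, so they could show nothing about this position alone. The change takes away a group of 4 heavy atoms with 2 hydrogen-bond acceptors and brings in one of 2 heavy atoms with 1 hydrogen-bond acceptor, but nothing shown separates these differences, and no measured finding given here bears on why the number rises.

Open, as far as these compounds go, is how an amine, a carboxylic acid or a sulfonamide on that aromatic carbon would read in this assay, and so whether methylsulfonyl or cyano is the unusual group of the two. From the compounds shown here alone, with a single step at this position, it also stays open whether the same change would count for as much on the other end of the molecule, such as the benzoate ester of compound 1, which reaches only a limit.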